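Allyl to methyl on the ring amine of compound 3

This account rests on a few compounds, and the source may have more. Where it says the series, first, only, none or still open, it means among the compounds named here.

Of the compounds shown here, three have been measured in an assay on isolated protein for displacement of a labelled ligand from D(1B) dopamine receptor (Homo sapiens); on this read-out higher numbers stand for weaker inhibition and lower numbers for stronger inhibition. Compound 1 `C=CCN1CCc2cc(OC)c(O)cc2C(c2ccccc2Br)C1` gives 501 nM. Compound 2 `C=CCN1CCc2cc(OC)c(O)cc2C(c2c(Cl)cccc2Cl)C1` gives 479 nM. Compound 3 `C=CCN1CCc2cc(O)c(O)cc2C(c2ccccc2Br)C1` gives 442 nM. The two steps recorded so far are both flat: a 1.0-fold lower number from compound 1 to compound 2 (0.02 log units; within the scatter) and a 1.1-fold lower number from compound 1 to compound 3 (0.05 log units; within the scatter). Compound 3 therefore stands within the scatter of both compound 1 and compound 2, and nothing separates the three on this read-out.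

Compound 4 `CN1CCc2cc(O)c(O)cc2C(c2ccccc2Br)C1` has not yet been measured. It differs from compound 3 by hydrogen in place of vinyl on a saturated chain carbon bound to an amine nitrogen in a ring.

Neither measured step bears directly on this change. Within the data shown here, the step from compound 1 to compound 2 alters the aryl group on the saturated ring carbon, and the step from compound 1 to compound 3 alters the oxygen substituent on the aromatic ring; no measured pair varies the substituent on the amine nitrogen in the ring. Among the measured compounds shown here, with no precedent for the allyl to methyl exchange, the expectation for compound 4 is anchored to compound 3 alone, with a range widened for the lack of data. The step of a 1.0-fold higher number from compound 3 to compound 4 (0.01 log units; within the scatter) is expected to be no larger than the scatter. Compound 4 is estimated at 450 nM, with a range from 150 nM to 1500 nM.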

Compound 4, inhibition constant: 223 nM
Beside the measured number, compound 4's estimate is 2.0-fold (0.30 log units) above it; the measured number falls inside the stated range.
By their numbers in this assay, from the lowest: compounds 4, 3, 2 and 1 (each within the scatter of the next, the first and the last beyond it).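

In this assay, the series now has its first step at the amine nitrogen in a ring, and allyl to methyl gives a 2.0-fold lower number from compound 3 to compound 4 (0.30 log units; within the scatter). Read as hydrogen in place of vinyl, the change removes two carbons and the only double bond outside the aromatic rings, yet the step stays within the scatter, so compounds 3 and 4 cannot be separated on this read-out and this one pair shows no sensitivity to the exchange. No measurement on hand offers an explanation for this result.

Among these compounds, the single pair leaves open whether the same exchange would stay as flat on the other aryl group, the 2,6-dichlorophenyl of compound 2, or with the methyl ether of compound 1 in place of the free hydroxyl. It also leaves open how far this position can be varied, since a hydrogen on the nitrogen, a longer chain such as n-butyl and a benzyl group are all absent from the compounds shown, and any of them could yield a step beyond the scatter.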